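Inverting one ring stereocentre on a potent quinazoline-type amine

A few compounds are considered here, and "the series" means these few. Any claim that something is new, unique, unknown or untested is made for them only; others in the source may bear on it.

Measured compounds:
compound 1, `COc1cc2nc(N3CCC[C@@H](N)C3)nc(N)c2cc1OC`: 102 nM
compound 2, `COc1cc2nc(N3CCC[C@H](NC4=CC(=O)c5ccccc5C4=O)C3)nc(N)c2cc1OC`: 2.14 nM

In an assay on CHO cells for displacement of a labelled ligand from Alpha-1D adrenergic receptor (Homo sapiens), with a stated time of 30 min (on this read-out lower numbers stand for stronger inhibition and higher numbers for weaker inhibition), compound 2 gives 2.14 nM, the lowest number of the two measured, and its gap to compound 1 lies well beyond the usual scatter. Compound 3, `COc1cc2nc(N3CCC[C@@H](NC4=CC(=O)c5ccccc5C4=O)C3)nc(N)c2cc1OC`, is the counterpart of compound 2 in which (the two compounds have the same atoms and bonds and differ only in configuration as drawn: 1 of 1 stereo elements differ; a stereocentre at a saturated ring carbon is drawn S in compound 2 and R in compound 3). Nothing else changes: the same atoms and bonds are present in both.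

Going by the values given here, no measured pair here differs by configuration alone, so the size of such a step cannot be read from the data. Swapping the configuration at a single stereocentre often changes binding noticeably, and usually toward weaker binding when the starting compound is the stronger one, as compound 2 is. The expected step from compound 2 to compound 3 in this assay is a 7.0-fold higher number from compound 2 to compound 3 (0.85 log units; beyond the scatter), a loss rather than a gain. Compound 3 is therefore estimated at 15 nM, within a range of 3 nM to 100 nM.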

Compound 3, inhibition constant: 33.9 nM
Beside the measured number, compound 3's estimate is 2.3-fold (0.35 log units) below it; measured number inside the range.
By their numbers in this assay, from the lowest: compound 2; then compound 3; then compound 1.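

Inverting the stereocentre at the saturated ring carbon from S to R produces, in this assay, a 16-fold higher number from compound 2 to compound 3 (1.20 log units; beyond the scatter), a large step. The earlier compounds shown here offered no pair that isolated configuration, whereas this pair shows that the spatial direction of the substituent at this carbon matters by itself, with the S form giving the stronger binding of the two. The step can be assigned to this single stereocentre because no other structural feature separates the pair: the fact that compounds 2 and 3 differ only in the configuration as drawn

From the compounds shown here alone, whether S remains the better configuration with a different group on that nitrogen, such as a benzoyl amide or a short alkyl chain, remains open. The compounds shown also do not reveal how the change in configuration produces this loss of binding.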